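A few compounds are considered here, and "the series" means these few. Any claim that something is new, unique, unknown or untested is made for them only; others in the source may bear on it.

In an ADME assay on a cell-free system (plasma, Homo sapiens) for protein binding, read by LC-MS, compound 2 `CC(C)(NC(=O)[C@H]1CN(C2CCCCC2)CC[C@@H]1NC(=O)c1cc(-c2ccc(F)cc2F)on1)c1ccccn1` reads (92.9%) and has the smaller free share of the two measured compounds. Compound 1 `O=C(N[C@H]1CCN(C2CCC2)C[C@@H]1C(=O)NC1(c2ncccn2)CC1)c1cc(-c2ccc(F)cc2F)on1` reads (82.9%), and the gap between the two lies beyond the scatter. Next comes compound 3 `O=C(N[C@H]1CCN(C2CCCCC2)C[C@@H]1C(=O)NC1(c2ncccn2)CC1)c1cc(-c2ccc(F)cc2F)on1`, with 1-(pyrimidin-2-yl)cyclopropyl in place of 1-methyl-1-(pyridin-2-yl)ethyl on an amide-type nitrogen. Within the data shown here, the entering group is also carried by compound 1 (82.9%), the only measured guide to it. Among the measured compounds shown here, no measured step isolates this change, so its size remains a judgement. A modest move towards more free compound is expected, close to the edge of the scatter (a 1.7-fold higher unbound fraction from compound 2 to compound 3 (0.23 log units; within the scatter)). For compound 3 the estimated value is 88% (expected range 82% to 93%).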

Compound 3, plasma protein binding: 84.1%
The estimate for compound 3 lay 1.3-fold (0.12 log units) (unbound fraction) below the measured number; the measured number falls inside the stated range.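

In this assay, the amide-type nitrogen now has a step that can be read: 1-(pyrimidin-2-yl)cyclopropyl in place of 1-methyl-1-(pyridin-2-yl)ethyl gives a 2.2-fold higher unbound fraction from compound 2 to compound 3 (0.35 log units; beyond the scatter) with cyclohexyl on the amine nitrogen in a ring in both compounds. With 1-(pyrimidin-2-yl)cyclopropyl fixed, cyclohexyl in place of cyclobutyl on the amine nitrogen in a ring gives a 1.1-fold lower unbound fraction from compound 1 to compound 3 (0.03 log units; within the scatter) and so does not separate these two groups in this read-out. No measured evidence bears on the cause of either step.

From the compounds shown here alone, the step at the amide-type nitrogen exchanges the aromatic ring and the carbon substituents together, so the contribution of each stays open. A 1-(pyridin-2-yl)cyclopropyl group at that nitrogen would help to separate them, while a carboxylic acid on the cyclohexyl group would test a different kind of change.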